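The source may hold more compounds than are shown below. What is called first, only, known or untested is meant among the compounds shown, and "the series" means these compounds.

Of the compounds shown here, three have been tested in an assay for inhibition of Indoleamine 2,3-dioxygenase 1 (Homo sapiens), with stated times of 10 min and 60 min, tested at 10 uM; on this read-out higher numbers stand for a stronger effect at the one concentration tested and lower numbers for a weaker effect. Compound 1, with the structure `FC(F)(F)c1cc(NC[C@H]2CCCN2)c2cn[nH]c2c1`, gives 34%. Compound 2, with the structure `O=C1NC(=O)c2c(NCc3ccccc3[N+](=O)[O-])cccc21`, gives 11%. Compound 3, with the structure `O=[N+]([O-])c1cccc(CNc2cc(Br)cc3[nH]ncc23)c1`, gives 72%, the highest of the three numbers; it stands beyond the usual scatter above both compound 1 and compound 2.

The next compound, compound 4 with the structure `O=[N+]([O-])c1cccc(CNc2cc(C(F)(F)F)cc3[nH]ncc23)c1`, keeps the whole of compound 3 except for one change: trifluoromethyl in place of bromo on an aromatic carbon. Compound 1 also carries a trifluoromethyl on its core but has a different side chain, so it does not isolate this swap. Within the data shown here, no measured pair shows this exact change, and the expectation rests on compound 3 alone.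

The step from compound 3 to compound 4 is expected to be small, most likely a modest fall, at a number 12 percentage points lower from compound 3 to compound 4 (beyond the scatter) in this assay. Compound 4 is therefore estimated to give about 60%, within a range from 35% to 80%.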

Compound 4, a percentage reported as inhibition, at one concentration (the size of the read-out at that concentration, not a potency): 45%
Beside the measured number, compound 4's estimate is 15 percentage points above it; measured number inside the range.
By their numbers in this assay, from the lowest: compound 2; then compound 1; then compound 4; then compound 3.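

With the rest of the molecule held constant, trifluoromethyl in place of bromo on this aromatic carbon, para to a fused ring, gives a number 27 percentage points lower from compound 3 to compound 4 (beyond the scatter) in this assay. Among these compounds, this is the first pair here that differs in only one place, and it shows that the group at this position affects the read-out: bromo and trifluoromethyl are not interchangeable, and bromo gives the higher number. No measurement at hand explains this step.

From the compounds shown here alone, whether chloro, methyl or a nitrile at this position would give a number closer to that of compound 3 or that of compound 4 remains open. Among the compounds shown here, also open is whether the same swap would produce a step of similar size with a different side chain, such as the one on compound 1.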